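The source may hold more compounds than are shown below. What is called first, only, known or untested is meant among the compounds shown, and "the series" means these compounds.

Working notes on the series. The shared core of compound 1 `O[C@@H](c1ccccc1)[C@H]1CO[C@H](c2ccccc2)[C@@H](C/C=C/c2ccccc2)C1` carries a hydroxyl-bearing benzylic arm and a 3-phenylprop-2-en-1-yl chain. Within the data shown here, in a functional assay on HeLa cells (Homo sapiens) for cytotoxicity, read by WST assay, with a stated time of 48 h (a lower number here means a stronger inhibitor, a higher number a weaker inhibitor), compound 1 gives 6060 nM, the only plain number in the set. Compound 2 `COc1ccc(/C=C/C[C@H]2C[C@@H]([C@@H](OC(C)=O)c3ccc(OC)c(OC)c3)CO[C@@H]2c2ccc(OC)c(OC)c2)cc1OC`, the acetylated and methoxylated relative, gives in this assay > 100000 nM, which is a limit of the assay rather than a number. Among the measured compounds shown here, compound 1 therefore stands as the single measured point, with the limit of > 100000 nM in this assay, at which 1 of the 2 values shown sits, as the only other reading. Compound 3 `O[C@@H](c1ccccc1)[C@H]1CO[C@H](c2ccccc2)[C@@H](C/C=C/c2cccnc2)C1` is not yet measured in this assay. The change from compound 1 to compound 3 is pyridin-3-yl in place of phenyl on a double-bonded chain carbon bound to a double-bonded chain carbon.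

For the measured compounds named here, no measured pair isolates this change, so it carries no evidence of its own. With compound 1 as the only anchor at 6060 nM, the step expected from compound 1 to compound 3 is a 1.2-fold higher number from compound 1 to compound 3 (0.06 log units; within the scatter), not beyond the scatter, in no firm direction. Compound 3 is estimated in this assay at 7000 nM, with a range from 2500 nM to 20000 nM.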

Compound 3, half-maximal inhibitory concentration: > 100000 nM
Compound 3: only a limit was reported; the forecaster's own chance of this, stated with the estimate: 10%; middle value at least 14-fold (1.15 log units) from the limit.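

Among these compounds, replacing phenyl with pyridin-3-yl on a double-bonded chain carbon bound to a double-bonded chain carbon is the first change read at a single place, and in this assay it gives an at least 16-fold higher number from compound 1 to compound 3 (1.21 log units; beyond the scatter). This position is therefore not indifferent to the ring it carries: with the rest of compound 1 kept, the exchange of this one ring is enough to carry compound 3 out of the measurable range. The reading of compound 3 is a limit of the assay and not a number, so the step has a lower bound only: the limit of > 100000 nM in this assay, at which 2 of the 3 values shown sit.

Going by these compounds, whether the loss belongs to the nitrogen at this ring position or to any departure from phenyl stays open; pyridin-4-yl or 4-fluorophenyl on the same chain would separate the two. On these data alone, how far compound 3 lies past the limit also stays open.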